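The source may hold more compounds than are shown below. What is called first, only, known or untested is meant among the compounds shown, and "the series" means these compounds.

Measured so far in an assay on HEK293 cells for agonist activity at transient receptor potential cation channel subfamily M member 8 (Homo sapiens), read by fluorescence and calcium flux, with a stated time of 15 min; on this read-out higher numbers stand for an effect only at larger amounts of compound and lower numbers for an effect already at smaller amounts:
compound 1 `CCN(Cc1cccs1)C(=O)COc1ccc(C)cc1`, 8 nM
compound 2 `CCN(Cc1cc[nH]n1)C(=O)COc1ccc(C)cc1`, "not active" (no number reported)
compound 3 `CCN(Cc1ccco1)C(=O)COc1ccc(C)cc1`, 489 nM

Compound 1 holds the lowest of the two numbers; the gap to the nearest is a 61-fold higher number from compound 1 to compound 3 (1.79 log units; beyond the scatter), and compound 2 yields no number at all. Compound 4 `Cc1ccc(OCC(=O)N(C)Cc2cccs2)cc1` keeps the thiophen-2-yl ring of compound 1 and differs only by hydrogen in place of methyl on a saturated chain carbon bound to an amide-type nitrogen. Among the compounds with values here, no measured step touches this position: the one measured step, a 61-fold higher number from compound 1 to compound 3 (1.79 log units; beyond the scatter), concerns exchange of the ring rather than the chain on the amide-type nitrogen, so it offers no direct guide. With nothing in the series against it, compound 4 is expected to stay near compound 1, with a 1.5-fold higher number from compound 1 to compound 4 (0.18 log units; within the scatter) inside the scatter. The estimate for compound 4 is 12 nM, with a range of 4 nM to 40 nM.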

Compound 4, half-maximal effective concentration: 400 nM
The estimate for compound 4 lay 33-fold (1.52 log units) below the measured number; the whole stated range lies below it.
By their numbers in this assay, from the lowest: compound 1; then compounds 4 and 3 (each within the scatter of the next).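

The ethyl on the amide-type nitrogen of compound 1 matters in this assay: with the thiophen-2-yl ring kept, ethyl to methyl alone gives a 50-fold higher number from compound 1 to compound 4 (1.70 log units; beyond the scatter). Within the data shown here, this position therefore responds strongly to a change of a single carbon, which the ring exchange in the earlier compounds could not show. Nothing available here accounts for the size of this step.

Open, on these data alone, is whether a longer chain such as propyl or butyl at this place gives a lower or a higher number than ethyl. Also open, as far as these compounds go, is whether the furan-2-yl ring responds to ethyl to methyl in the same way.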